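The source may report more compounds than this note shows. Statements on the series, on what has been measured and on what is new or still open speak of the compounds shown alone.

Three diaryl ureas sharing one core have been measured in a functional assay on MDA-MB-435 cells (Homo sapiens) for inhibition, read by sulforhodamine B assay, with a stated time of 48 h; a higher number here means a weaker inhibitor of growth, a lower number a stronger inhibitor of growth. Compound 1 `COc1cc(-c2nn(-c3cccc(NC(=O)Nc4cc(C(F)(F)F)cc(C(F)(F)F)c4)c3)cc2-c2ccncc2)ccc1Cl` gives 1990 nM in this assay. Compound 2 `COc1cc(-c2nn(-c3cccc(NC(=O)Nc4ccc(Cl)c(Cl)c4)c3)cc2-c2ccncc2)ccc1Cl` gives 2390 nM in this assay, and the gap between compound 1 and compound 2 lies within the scatter, so nothing separates them. How the two cores of compound 1 and compound 2 differ is not broken down here. Compound 3 `O=C(Nc1cccc(-n2cc(-c3ccncc3)c(-c3ccc(Cl)c(O)c3)n2)c1)Nc1ccc(Cl)c(Cl)c1` is made from compound 2 by a single change, hydrogen in place of methyl on an oxygen on an aromatic ring and in this assay compound 3 gives 6050 nM. The resulting step, a 2.5-fold higher number from compound 2 to compound 3 (0.40 log units; beyond the scatter), lies beyond the scatter and is modest in size.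

Compound 4 `O=C(Nc1cccc(-n2cc(-c3ccncc3)c(-c3ccc(Cl)c(O)c3)n2)c1)Nc1cc(C(F)(F)F)cc(C(F)(F)F)c1` has not yet been measured. It differs from compound 1 by hydrogen in place of methyl on an oxygen on an aromatic ring The place of this change is the same, word for word, as in the change from compound 2 to compound 3, so it is the same change made on the core of compound 1 instead of compound 2. Among the compounds shown this change appears twice in all, and only once with a measured outcome.

Going by the values given here, the expectation for compound 4 is that its step will be a 2.5-fold higher number from compound 1 to compound 4 (0.40 log units; beyond the scatter), similar to the measured step because a 2.5-fold higher number from compound 2 to compound 3 (0.40 log units; beyond the scatter) is the only guide available. Compound 4 is therefore estimated at 5000 nM in this assay. Its expected range runs from 2500 nM to 10000 nM, held wide since a single pair supports it.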

Compound 4, concentration for total growth inhibition: 2590 nM
Compound 4: the middle estimate sits 1.9-fold (0.29 log units) above what was measured; measured number inside the range.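

Going from methoxy to hydroxy on the core of compound 1 gives a 1.3-fold higher number from compound 1 to compound 4 (0.11 log units; within the scatter) in this assay, so on this core the change does not separate the two compounds, whereas on the core of compound 2 its step lay beyond the scatter. Set side by side, the two steps cannot be told apart: the same change on two cores in this assay, a 2.5-fold higher number (0.40 log units; beyond the scatter) from compound 2 to compound 3 and a 1.3-fold higher number (0.11 log units; within the scatter) from compound 1 to compound 4, 1.9-fold (0.29 log units) apart, within the scatter of two such steps The two pairs therefore fit a change that carries over from one core to the other with a similar size, but they do not show that it does so, nor that the core alters the outcome, as one step can be read and the other cannot, and two pairs are too few to fix the size of the change on either core.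

The compounds shown leave open how an ethoxy group, a longer alkoxy chain or an amine in place of the methoxy would read in this assay. They also leave open whether the change from methoxy to hydroxy would hold on a core whose urea carries a different aryl group, such as a phenyl ring bearing a nitrile or a carboxylic acid.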